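Quinoline to benzothiazole: stability of compound 4 in microsomes

The source may hold more compounds than are shown below. What is called first, only, known or untested is meant among the compounds shown, and "the series" means these compounds.

Measured compounds:
compound 1, `Cc1cc(F)cnc1N1CCN(C(=O)CCCc2cccc3ncc(CO)cc23)[C@@H](C)C1`: 1%
compound 2, `Cc1cc(F)cnc1N1CCN(C(=O)CCCc2cccc3cncnc23)[C@@H](C)C1`: "not determined" (no result reported)
compound 3, `Cc1cc(F)cnc1N1CCN(C(=O)CCCc2cccc3ncccc23)[C@@H](C)C1`: 0.2%
compound 4, `Cc1cc(F)cnc1N1CCN(C(=O)CCCc2cccc3ncsc23)[C@@H](C)C1`: not yet measured

In an ADME assay on microsomes from liver (Rattus norvegicus) for metabolic stability, read by LC-MS, with a stated time of 15 min, tested at 1 uM (on this read-out higher numbers stand for a more stable compound and lower numbers for a less stable compound), compound 3 gives 0.2%. That is the lowest of the two numbers reported, and its nearest neighbour is compound 1 with 1%; the two lie within the scatter of each other, so neither can be called the more stable. Compound 2 has no result in this assay.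

Within the data shown here, the single step measured between compounds that differ in one place is a number 0.8 percentage points lower from compound 1 to compound 3 (within the scatter). It exchanges a hydroxymethyl for hydrogen on an aromatic carbon and leaves the numbers essentially where they were.

Compound 4 differs from compound 3 as follows: 1,3-benzothiazol-7-yl in place of quinolin-5-yl on a saturated chain carbon, three bonds along the chain from a carbonyl carbon

Among the measured compounds shown here, no measured step exchanges the ring system that this change exchanges, so the measured step gives no direct guide to its size. What the data show is that both measured compounds sit at the very bottom of the scale in this assay. On that basis compound 4 is expected to remain near the bottom as well, with a step of a number 0.8 percentage points higher from compound 3 to compound 4 (within the scatter) that is not expected to exceed the scatter. Compound 4 is therefore estimated to give 1% in this assay, within a range from 0% to 8%.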

Compound 4, percent of the compound remaining: 5.3%
For compound 4 the middle estimate is 4.3 percentage points below the measured one; low and high end bracket the measured number.
By their numbers in this assay, from the lowest: compounds 3, 1 and 4 (each within the scatter of the next).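

The exchange of quinolin-5-yl for 1,3-benzothiazol-7-yl on the saturated chain carbon, three bonds along the chain from a carbonyl carbon, amounts in this assay to a number 5.1 percentage points higher from compound 3 to compound 4 (within the scatter). The earlier compounds shown here showed only what a hydroxymethyl group does on an aromatic carbon; this step shows that the whole ring system at this place can be exchanged, with a five-membered aromatic ring with 2 hetero atoms entering for a six-membered one, and the numbers still stay within the scatter of each other. So this change, taken alone, does not establish any difference in stability between the two compounds, and nothing at hand accounts for the size of the step.

From the compounds shown here alone, what stays open is whether any group at this place can carry a compound beyond the scatter of compound 3 in this assay. An amine or a carboxylic acid on the 1,3-benzothiazol-7-yl group, or a longer chain leading to the carbonyl carbon, might answer that, and the compounds shown do not say which way such a change would go.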